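A few compounds are considered here, and "the series" means these few. Any claim that something is new, unique, unknown or untested is made for them only; others in the source may bear on it.

Three compounds have been measured in a functional assay on RXF 393 cells (Homo sapiens) for inhibition, read by sulforhodamine B assay, with a stated time of 48 h; on this read-out higher numbers stand for weaker inhibition of growth and lower numbers for stronger inhibition of growth:

Compound 1, `Nc1cc(N)c2nc(-c3ccccc3)c(NCc3ccc(Cl)c(Cl)c3)nc2c1`, gives 3090 nM.
Compound 2, `COc1ccc(CNc2nc3cc(N)cc(N)c3nc2-c2ccccc2)cc1OC`, gives 19100 nM.
Compound 3, `CCOC(=O)[C@H](CCC(=O)O)NC(=O)c1ccc(Sc2nc3cc(N)cc(N)c3nc2-c2ccccc2)cc1`, gives 20000 nM.

Compound 2 stands second highest of the three numbers. For the measured compounds named here, compound 2 and compound 3 lie within the usual scatter of each other, while compound 1 lies well below both; the only single-point step in the set, a 6.2-fold higher number from compound 1 to compound 2 (0.79 log units; beyond the scatter), is the one that separates compound 1 from compound 2.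

Compound 4, `COc1cc(CNc2nc3cc(N)cc(N)c3nc2-c2ccccc2)cc(OC)c1OC`, has not been measured. It differs from compound 2 in one place: methoxy in place of hydrogen on an aromatic carbon. Going by the values given here, no measured step tests this kind of change. Among the compounds with values here, the one step at hand, from compound 1 to compound 2, exchanged two chlorines for two methoxy groups on that same ring and raised the number, but it says nothing about adding a third methoxy group to a ring that already carries two. Without a step that bears directly on the change, a step of a 1.0-fold higher number from compound 2 to compound 4 (0.02 log units; within the scatter) is expected in this assay, that is, no change beyond the scatter. Compound 4 is therefore estimated at 20000 nM, with a range from 8000 nM to 50000 nM.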

Compound 4, concentration for 50% growth inhibition: 7410 nM
Estimate against measurement, compound 4: 2.7-fold (0.43 log units) above, outside the stated range (below it).
By their numbers in this assay, from the lowest: compound 1; then compound 4; then compounds 2 and 3 (each within the scatter of the next).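

In this assay, methoxy in place of hydrogen on this aromatic carbon, ortho to a methoxy group and meta to a large group, gives a 2.6-fold lower number from compound 2 to compound 4 (0.41 log units; beyond the scatter), a modest move beyond the scatter towards stronger inhibition of growth. This shows that the carbon is not a silent spot on the ring: a small group added there changes the read-out, even on a ring that already carries methoxy groups. It also adds a needed qualification to the earlier step, a 6.2-fold higher number from compound 1 to compound 2 (0.79 log units; beyond the scatter), in which methoxy groups in place of chlorines went with weaker inhibition, since here one more methoxy group goes with stronger inhibition, so methoxy on this ring does not push the number in a single direction. No measurement at hand says why the number falls with this change.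

As far as these compounds go, whether the gain belongs to methoxy itself or would also come with a different group on this carbon, such as a hydroxyl, a fluorine or an amine, remains open. So does whether the same addition would lower the number on the chlorine-bearing ring of compound 1.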